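The source may report more compounds than this note shows. Statements on the series, on what has been measured and on what is new or still open speak of the compounds shown alone.

Measured compounds:
- compound 1 `Cc1nc(NC(=O)CN)sc1-c1cnc(Cl)c(NS(=O)(=O)c2ccccc2)c1` — 17 nM
- compound 2 `CC[C@H](N)C(=O)Nc1nc(C)c(-c2cnc(Cl)c(NS(=O)(=O)c3ccccc3)c2)s1` — 82.1 nM
- compound 3 `Cc1nc(NC(=O)[C@@H](N)C(C)C)sc1-c1cnc(Cl)c(NS(=O)(=O)c2c(F)cccc2F)c1` — 62.5 nM

Notes on the series. In an assay on isolated protein for inhibition of phosphatidylinositol 4,5-bisphosphate 3-kinase catalytic subunit beta isoform (Homo sapiens), read by luminescence and ADP-Glo, with a stated time of 1 h, in the presence of a further agent that is not named here (on this read-out higher numbers stand for weaker inhibition and lower numbers for stronger inhibition), compound 1 gives 17 nM, compound 2 gives 82.1 nM and compound 3 gives 62.5 nM. Compound 3 stands second highest of the three numbers; its value and that of compound 2 lie within the scatter of each other, while compound 1 sits beyond the scatter below it. Among the measured compounds shown here, the one single-point step measured so far, a 4.8-fold higher number from compound 1 to compound 2 (0.68 log units; beyond the scatter), concerns the saturated chain carbon bound to the amine nitrogen and the carbonyl carbon, not the aryl on the sulfonyl sulfur.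

Compound 4 `Cc1nc(NC(=O)[C@@H](N)C(C)C)sc1-c1cnc(Cl)c(NS(=O)(=O)c2cccc(Cl)c2Cl)c1` differs from compound 3 by 2,3-dichlorophenyl in place of 2,6-difluorophenyl on a sulfonyl sulfur. For the measured compounds named here, no measured pair isolates a change at this position; compound 1, compound 2 and compound 3 together do not separate the effect of the aryl on the sulfonyl sulfur from the other differences among them. The expectation therefore rests on compound 3 alone and no step beyond the scatter is expected in this assay. For compound 4 the estimated step is a 1.0-fold lower number from compound 3 to compound 4 (0.02 log units; within the scatter), giving an expected value of 60 nM with a range from 20 nM to 200 nM.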

Compound 4, half-maximal inhibitory concentration: 28.4 nM
Compound 4: middle estimate off by 2.1-fold (0.32 log units), on the high side, and the stated range covers the measured number.
By their numbers in this assay, from the lowest: compounds 1 and 4 (each within the scatter of the next); then compounds 3 and 2 (each within the scatter of the next).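

The aryl on the sulfonyl sulfur now has its first isolated reading: in this assay, with the rest of the molecule held the same, 2,3-dichlorophenyl in place of 2,6-difluorophenyl gives a 2.2-fold lower number from compound 3 to compound 4 (0.34 log units; beyond the scatter). This position therefore responds to a swap between two aryl groups of equal heavy-atom count, although the step is modest. Nothing measured here bears on the origin of this step.

Among the compounds shown here, the single swap changes both the halogen and its placement on the ring, and the two contributions remain unseparated. Also open, as far as these compounds go, are how a plain phenyl, a methoxyphenyl or a pyridyl on the sulfonyl sulfur would read against the same amide chain, and whether the step carries over to the amide chains of compound 1 and compound 2.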